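This account rests on a few compounds, and the source may have more. Where it says the series, first, only, none or still open, it means among the compounds named here.

Series notes, sulfonamide-capped peptides against an assay on isolated protein for inhibition of Matrilysin (Homo sapiens), read by fluorescence, with a stated time of 15 min; a lower number here means a stronger inhibitor, a higher number a weaker inhibitor. Compound 1 `CSCC[C@H](NC(=O)[C@H](C)NC(=O)[C@H](C)NC(=O)CC[C@H](NS(=O)(=O)c1ccc(Cl)c(C(F)(F)F)c1)C(=O)O)C(N)=O` gives 6700 nM; compound 2 `CSCC[C@H](NC(=O)[C@H](CC(C)C)NC(=O)[C@H](CC(C)C)NC(=O)CC[C@H](NS(=O)(=O)c1ccc(Cl)c(C(F)(F)F)c1)C(=O)O)C(N)=O` gives 780 nM; compound 3 `CSCC[C@H](NC(=O)[C@H](CC(C)C)NC(=O)[C@H](C)NC(=O)C[C@H](NS(=O)(=O)c1ccc(Cl)c(C(F)(F)F)c1)C(=O)O)C(N)=O` gives 4700 nM. Compound 2 holds the lowest number of the three, beyond the scatter from compound 3 and further still from compound 1. Compound 4 `CSCC[C@H](NC(=O)[C@H](CC(C)C)NC(=O)[C@H](CCC(N)=O)NC(=O)CC[C@H](NS(=O)(=O)c1ccc(Cl)c(C(F)(F)F)c1)C(=O)O)C(N)=O` has not yet been measured in this assay. It differs from compound 2 by carbamoylmethyl in place of isopropyl on a saturated chain carbon, two bonds along the chain from an amide-type nitrogen and a carbonyl carbon. With compound 1 at 6700 nM showing that trimming the side chains in this region raises the number, a step of moderate size toward a higher number is expected, rather than none beyond the scatter. On that basis the expected step from compound 2 to compound 4 is a 3.8-fold higher number from compound 2 to compound 4 (0.59 log units; beyond the scatter), and compound 4 is estimated at 3000 nM, within 1200 nM to 8000 nM.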

Compound 4, half-maximal inhibitory concentration: 1300 nM
The estimate for compound 4 lay 2.3-fold (0.36 log units) above the measured number, within the range that was stated.
By their numbers in this assay, from the lowest: compounds 2 and 4 (each within the scatter of the next); then compounds 3 and 1 (each within the scatter of the next).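

On a saturated chain carbon, two bonds along the chain from an amide-type nitrogen and a carbonyl carbon, carbamoylmethyl in place of isopropyl gives no change beyond the scatter (a 1.7-fold higher number from compound 2 to compound 4 (0.22 log units; within the scatter)). Among the compounds shown here, this is the first single-place comparison, and it shows that this position accepts a hydrogen-bond donor and a hydrogen-bond acceptor where isopropyl has neither. No supporting measurement bears on why the step is this small. On these data alone, whether an amine, a carboxylic acid or a longer chain at this carbon would also stay within the scatter of compound 2 remains open.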